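Pyrrole carboxamide series: tertiary amide variation at the carbonyl

This account rests on a few compounds, and the source may have more. Where it says the series, first, only, none or still open, it means among the compounds named here.

Compound 3 `C=CCN(C)C(=O)c1ccc(C(CC)(CC)c2ccc(OCC(=O)C(C)(C)C)c(C)c2)n1CC` gives 21600 nM in an assay on HL-60 cells for agonist activity at vitamin D3 receptor (Homo sapiens), read by microscopy, with a stated time of 96 h (a lower number here means that less compound is needed, a higher number that more compound is needed for the effect), the highest of the three numbers measured. Its nearest neighbour is compound 1 `C#CCNC(=O)c1ccc(C(CC)(CC)c2ccc(OCC(=O)C(C)(C)C)c(C)c2)n1CC`, which gives 2200 nM; the furthest is compound 2 `CCn1c(C(=O)NCC(OC)OC)ccc1C(CC)(CC)c1ccc(OCC(=O)C(C)(C)C)c(C)c1`, which gives 130 nM. The two steps into compound 3 both raised the number: a 9.8-fold higher number from compound 1 to compound 3 (0.99 log units; beyond the scatter), and a 170-fold higher number from compound 2 to compound 3 (2.22 log units; beyond the scatter). The step between the two secondary amides went the other way: a 17-fold lower number from compound 1 to compound 2 (1.23 log units; beyond the scatter).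

Compound 4 `CCn1c(C(=O)N(CCC#N)CCC#N)ccc1C(CC)(CC)c1ccc(OCC(=O)C(C)(C)C)c(C)c1` keeps the shared core and differs from compound 3 only at the amide: a group of 9 heavy atoms (6 carbon, 3 nitrogen; no ring) in place of a group of 5 heavy atoms (4 carbon, 1 nitrogen; no ring), on a carbonyl carbon. Like compound 3 it is a tertiary amide, and the two steps that bear on it, a 9.8-fold higher number from compound 1 to compound 3 (0.99 log units; beyond the scatter) and a 170-fold higher number from compound 2 to compound 3 (2.22 log units; beyond the scatter), show that the tertiary allyl(methyl) amide sits far above both secondary amides. Among the measured compounds shown here, no measured step replaces one tertiary amide with another, so the size of the change is uncertain. For the measured compounds named here, the entering group brings two hydrogen-bond acceptors, and the only measured compound with acceptors on the amide chain, compound 2, gives 130 nM; on that weak ground a step of a 2.7-fold lower number from compound 3 to compound 4 (0.43 log units; beyond the scatter) is expected, downward, beyond the scatter but with a wide range. Compound 4 is therefore estimated at 8000 nM in this assay, between 1500 nM and 40000 nM.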

Compound 4, half-maximal effective concentration: 870 nM
Beside the measured number, compound 4's estimate is 9.2-fold (0.96 log units) above it; the measured number lies below the stated range.
By their numbers in this assay, from the lowest: compound 2; then compound 4; then compound 1; then compound 3.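

In this assay a tertiary amide on this carbonyl carbon is not tied to the top of the range: the change of groups gives a 25-fold lower number from compound 3 to compound 4 (1.39 log units; beyond the scatter) with no amide hydrogen on either side. The earlier order of secondary amides under the tertiary amide now holds only in part, as a 2.5-fold lower number from compound 1 to compound 4 (0.40 log units; beyond the scatter) places a tertiary amide under the propargylamino amide, whereas a 6.7-fold higher number from compound 2 to compound 4 (0.83 log units; beyond the scatter) leaves the (2,2-dimethoxyethyl)amino amide lowest of the four. No measured evidence on these groups is at hand, so the steps stand as sizes without an explanation.

Which feature of the entering group carries the step stays open, since the nitrile ends, the chain length and the presence of two such chains on one nitrogen all change together here. A dipropylamino amide, a bis(methoxyethyl)amino amide or a secondary amide with a single cyanoethyl chain would separate these features, and a morpholine amide would test a ring on the same carbonyl carbon.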